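The compounds below may be only part of what the source reports. "The series", "measured", "known", "first", "only" and "open" are said of these compounds alone.

In a functional assay on KG-1 cells (Homo sapiens) for cytotoxicity, read by luminescence and CellTiter-Glo, with a stated time of 3 days (on this read-out lower numbers stand for stronger inhibition and higher numbers for weaker inhibition), compound 1 `COc1ccc(O)c(C(=O)Nc2ccc(C#N)cc2)c1` reads > 10000 nM, which is a limit of the assay and not a number. Compound 2 `N#Cc1ccc(NC(=O)c2cc(-c3cccnc3)ccc2O)cc1` gives 8330 nM. For the measured compounds named here, compound 3 `N#Cc1ccc(NC(=O)c2cc(Cl)ccc2O)cc1` gives 1860 nM, the lowest number so far. Compound 4 `N#Cc1ccc(NC(=O)c2cc(C(F)(F)F)ccc2O)cc1` carries trifluoromethyl in place of chloro on an aromatic carbon, para to a hydroxy group: trifluoromethyl in place of chloro on an aromatic carbon. Two measured steps change the group at this place and arrive at chloro: an at least 5.3-fold lower number from compound 1 to compound 3 (0.73 log units; beyond the scatter) and a 4.5-fold lower number from compound 2 to compound 3 (0.65 log units; beyond the scatter). Neither involves trifluoromethyl, so they give no direction for this exchange, and no shift beyond the scatter is expected in this assay. The expected step is a 1.0-fold lower number from compound 3 to compound 4 (0.01 log units; within the scatter). For compound 4 the estimated value is 1800 nM, within an expected range of 700 nM to 5000 nM.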

Compound 4, half-maximal inhibitory concentration: 4810 nM
Compound 4: middle estimate off by 2.7-fold (0.43 log units), on the low side, and the stated range covers the measured number.
By their numbers in this assay, from the lowest: compound 3; then compounds 4 and 2 (each within the scatter of the next). At a limit, above all of these: compound 1.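

In this assay, trifluoromethyl proves no equal of chloro at this place, para to a hydroxy group, with a 2.6-fold higher number from compound 3 to compound 4 (0.41 log units; beyond the scatter), while a 1.7-fold lower number from compound 2 to compound 4 (0.24 log units; within the scatter) leaves it unseparated from pyridin-3-yl. Compound 1 reads > 10000 nM, which is a limit of the assay and not a number. Against that limit, the exchange of methoxy for trifluoromethyl gives only a floor: an at least 2.0-fold lower number from compound 1 to compound 4 (0.31 log units; beyond the scatter). The compounds shown leave open how bromo, an amine or a carboxylic acid would read at this place. They also do not say why chloro gives the lower number here.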